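Hydrogen in place of methyl on an aromatic oxygen

This account rests on a few compounds, and the source may have more. Where it says the series, first, only, none or still open, it means among the compounds named here.

Two compounds sharing one core have been examined in a functional assay on HCT-116 cells (Homo sapiens) for cytotoxicity, read by MTT assay; a lower number here means a stronger inhibitor, a higher number a weaker inhibitor. Compound 1 `Cc1c(O)cc(CCCCC(C)[C@H](C)O)oc1=O` gives only a limit of the assay there, > 200000 nM. Compound 2 `COc1cc(CCCCC(C)(C)O)oc(=O)c1C` likewise gives only a limit, > 200000 nM. Both results sit at the limit of > 200000 nM in this assay, at which 2 of the 2 values shown sit, so compound 2 stands at the limit and not at a number. Compound 3 `Cc1c(O)cc(CCCCC(C)(C)O)oc1=O` differs from compound 2 in a single place: hydrogen in place of methyl on an oxygen on an aromatic ring. Among the compounds with values here, no step between measured compounds is available, and the change from compound 2 to compound 3 is small. The step in this assay is therefore expected to stay within the scatter, in no particular direction, which is what a step that the limit leaves unreadable from compound 2 to compound 3 means. Compound 3 is expected to give 300000 nM, in a range from 100000 nM to 1000000 nM, most probably reported once more as a limit rather than a number.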

Compound 3, half-maximal inhibitory concentration: > 200000 nM
Compound 3 gave a limit, no number (the forecaster's own chance of this, stated with the estimate: 85%); the middle value does not contradict the limit.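

Compound 1, compound 2 and compound 3 all give only a limit in this assay, so no step from compound 2 or compound 1 to compound 3 can be read: the limit of > 200000 nM in this assay, at which 3 of the 3 values shown sit.

The compounds shown leave open whether methoxy to hydroxy changes the read-out in this assay at all.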